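From compound 3 to its 2-chlorophenyl analogue

The source may report more compounds than this note shows. Statements on the series, on what has been measured and on what is new or still open speak of the compounds shown alone.

In a functional assay on SK-OV-3 cells (Homo sapiens) for inhibition, read by sulforhodamine B assay, with a stated time of 48 h (on this read-out lower numbers stand for stronger inhibition of growth and higher numbers for weaker inhibition of growth), compound 1 (`Cc1ccc(NC(=O)/C=C/c2ccccc2)c(C(N)=O)c1`) gives 2790 nM, compound 2 (`NC(=O)c1cc(Br)ccc1NC(=O)/C=C/c1ccccc1`) gives 1410 nM and compound 3 (`NC(=O)c1cc(I)ccc1NC(=O)/C=C/c1ccccc1`) gives 744 nM. Compound 3 shares the low end of these numbers with compound 2, as a 1.9-fold lower number from compound 2 to compound 3 (0.28 log units; within the scatter) shows. The other steps are a 2.0-fold lower number from compound 1 to compound 2 (0.30 log units; within the scatter) and a 3.8-fold lower number from compound 1 to compound 3 (0.57 log units; beyond the scatter), and only the last of these clears the scatter.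

Compound 4 (`NC(=O)c1cc(I)ccc1NC(=O)/C=C/c1ccccc1Cl`) differs from compound 3 in one place: chloro in place of hydrogen on an aromatic carbon. This is chloro in place of hydrogen on an aromatic carbon, or phenyl to 2-chlorophenyl. All three measured steps exchange methyl, bromo and iodo at another place on the core, so they bear on this change only as a guide to size. The largest is a 3.8-fold lower number from compound 1 to compound 3 (0.57 log units; beyond the scatter). Going by the values given here, no measured compound carries a change on the phenyl, so no direction can be read, and no step beyond the scatter is expected in this assay. The expected step is a 1.1-fold lower number from compound 3 to compound 4 (0.03 log units; within the scatter). The estimate for compound 4 is 700 nM, with an expected range of 280 nM to 1800 nM.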

Compound 4, concentration for 50% growth inhibition: 539 nM
Compound 4: the middle estimate sits 1.3-fold (0.11 log units) above what was measured; the measured number falls inside the stated range.
By their numbers in this assay, from the lowest: compounds 4, 3, 2 and 1 (each within the scatter of the next, the first and the last beyond it).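

Chloro in place of hydrogen on the phenyl gives a 1.4-fold lower number from compound 3 to compound 4 (0.14 log units; within the scatter) in this assay, so this aromatic carbon, ortho to a large group, carries the chlorine with no step that clears the scatter. Going by these compounds alone, this is the first reading on the phenyl: the earlier compounds vary only methyl, bromo and iodo at another place on the core, and they say nothing about this ring. No measurement at hand bears on why the step from phenyl to 2-chlorophenyl is this small.

From the compounds shown here alone, whether the same step holds with bromo or methyl on the core in place of iodo remains open. Also open, going by these compounds, is how an amine, a carboxylic acid or a methoxy group would read at this carbon, and how chloro would read at other carbons of the phenyl.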